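Swapping the imidazole amide for a vinyl sulfone amide

The source may hold more compounds than are shown below. What is called first, only, known or untested is meant among the compounds shown, and "the series" means these compounds.

Measured so far, in a functional assay on MKN-45 cells (Homo sapiens) for cytotoxicity, read by MTT assay, with a stated time of 72 h; a lower number here means a stronger inhibitor, a higher number a weaker inhibitor:
compound 1 `COc1cc2c(Oc3ccc(NC(=O)c4cn(-c5ccccc5OC(F)(F)F)cn4)cc3F)ccnc2cc1OCCCN1CCCCC1`: 190 nM
compound 2 `COc1cc2c(Oc3ccc(NC(=O)c4cn(-c5ccc(Cl)cc5)cn4)cc3F)ccnc2cc1OCCCN1CCCCC1`: 5910 nM
compound 3 `COc1cc2c(Oc3ccc(NC(=O)c4cn(-c5ccc(Cl)cc5Cl)cn4)cc3F)ccnc2cc1OCCCN1CCCCC1`: 6240 nM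

Compound 2 stands second highest of these three numbers in this assay, with compound 3 giving a number within the scatter of it (a 1.1-fold higher number from compound 2 to compound 3 (0.02 log units; within the scatter)) and compound 1 far lower (a 31-fold higher number from compound 1 to compound 2 (1.49 log units; beyond the scatter)). Compound 4 `COc1cc2c(Oc3ccc(NC(=O)/C=C/S(=O)(=O)c4ccc(C)cc4)cc3F)ccnc2cc1OCCCN1CCCCC1` differs from compound 2 by 2-((4-methylphenyl)sulfonyl)ethenyl in place of 1-(4-chlorophenyl)-1H-imidazol-4-yl on a carbonyl carbon. Within the data shown here, none of the measured steps touches this part of the molecule; they concern only the ring on the aromatic nitrogen, which is gone in compound 4. The direction and size of the step in this assay are therefore open. The expected step from compound 2 to compound 4 is a 3.0-fold lower number from compound 2 to compound 4 (0.47 log units; beyond the scatter), and compound 4 is estimated at 2000 nM, between 300 nM and 15000 nM.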

Compound 4, half-maximal inhibitory concentration: 1690 nM
Estimate against measurement, compound 4: 1.2-fold (0.07 log units) above; the range from low to high includes it.
By their numbers in this assay, from the lowest: compound 1; then compound 4; then compounds 2 and 3 (each within the scatter of the next).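

In this assay, the group on the carbonyl carbon need not contain an imidazole: 2-((4-methylphenyl)sulfonyl)ethenyl in place of 1-(4-chlorophenyl)-1H-imidazol-4-yl gives a 3.5-fold lower number from compound 2 to compound 4 (0.54 log units; beyond the scatter). The earlier steps shown here changed only the ring on the aromatic nitrogen, so they could not show that replacing the whole group gives a modest gain. Nothing available explains this step.

The compounds shown leave open which part of the new group matters. An ethyl link in place of the ethenyl, or a methoxy in place of the ring methyl, would help separate these parts.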